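The source may report more compounds than this note shows. Statements on the series, on what has been measured and on what is new or still open speak of the compounds shown alone.

Going by the values given here, in a functional assay on MM1.S cells (Homo sapiens) for antiproliferative activity, read by luminescence, with a stated time of 72 h (on this read-out lower numbers stand for stronger inhibition and higher numbers for weaker inhibition), compound 1 (`Oc1ccc(Cn2cnc(F)c2)c2cccnc12`) gives 1200 nM and is the only compound with a number. Compound 2 (`CC(=O)Oc1ccc(Cn2ccnc2)c2cccnc12`) has no place on that scale, its entry being "not determined" (no result reported) in this set. Compound 3 (`CC(C)(C)OC(=O)Oc1ccc(Cn2c(-c3cscn3)nc3ccccc32)c2cccnc12`) is in the same position ("not determined" (no result reported)). The step to compound 4 (`CC(C)(CCl)C(=O)Oc1ccc(Cn2ccnc2)c2cccnc12`) reads 1-(chloromethyl)-1-methylethyl in place of methyl on a carbonyl carbon and amounts to 1-(chloromethyl)-1-methylethyl in place of methyl on a carbonyl carbon. Among the compounds with values here, no measured step exists to size this change, so in this assay no shift beyond the usual scatter is expected in either direction. Within the data shown here, the sole anchor is compound 1 at 1200 nM on the shared read-out, and the range is kept wide. For compound 4 the estimated value is 1000 nM (expected range 250 nM to 5000 nM).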

Compound 4, half-maximal inhibitory concentration: 3600 nM
Compound 4: middle estimate off by 3.6-fold (0.56 log units), on the low side, within the range that was stated.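

Compound 4, at 3600 nM, yields no readable step from compound 2, which carries no single number. The compounds shown leave open how 1-(chloromethyl)-1-methylethyl in place of methyl shifts activity. No supporting evidence bears on this result.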